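The compounds below may be only part of what the source reports. "The series", "measured", "known", "first", "only" and "open" are said of these compounds alone.

Measured compounds in a functional assay on NCI-H460 cells (Homo sapiens) for antiproliferative activity, read by XTT assay, with a stated time of 72 h; on this read-out higher numbers stand for weaker inhibition and lower numbers for stronger inhibition:

- compound 1, `COc1ccc(-c2cc3ccccc3nc2/C=C/C(=O)c2ccccc2)cc1`: 6670 nM
- compound 2, `COc1ccc(-c2cc3ccccc3nc2/C=C/C(=O)c2ccccn2)cc1`: 6260 nM

In this assay compound 2 and compound 1 give numbers that lie within the scatter of each other, so neither can be set above or below the other on these two values; the exchange of phenyl for pyridin-2-yl on the carbonyl carbon, a 1.1-fold lower number from compound 1 to compound 2 (0.03 log units; within the scatter), moved nothing beyond the noise.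

Compound 3, `COc1ccc(-c2cc3ccccc3nc2/C=C/C(=O)c2ccsc2)cc1`, has not yet been measured in this assay. It differs from compound 2 in one place: thiophen-3-yl in place of pyridin-2-yl on a carbonyl carbon. For the measured compounds named here, the only measured step that bears on this position is the one from compound 1 to compound 2, and it was within the scatter. Going by the values given here, replacing one six-membered aromatic ring with one hetero atom by a five-membered aromatic ring with one hetero atom at the same place has no direct precedent, so the expectation rests on the insensitivity of this position seen so far. The expected step is a 1.0-fold lower number from compound 2 to compound 3 (0.02 log units; within the scatter), that is, no change beyond the scatter. Compound 3 is estimated at 6000 nM, within a range from 2500 nM to 14000 nM.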

Compound 3, half-maximal inhibitory concentration: 7080 nM
Beside the measured number, compound 3's estimate is 1.2-fold (0.07 log units) below it, and the stated range covers the measured number.
By their numbers in this assay, from the lowest: compounds 2, 1 and 3 (each within the scatter of the next).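

Thiophen-3-yl in place of pyridin-2-yl on the carbonyl carbon gives a 1.1-fold higher number from compound 2 to compound 3 (0.05 log units; within the scatter) in this assay, and in place of phenyl it gives a 1.1-fold higher number from compound 1 to compound 3 (0.03 log units; within the scatter). The earlier pair covered only six-membered aromatic rings, so the insensitivity of this place now extends to a five-membered aromatic ring and to sulfur as its hetero atom. Phenyl, pyridin-2-yl and thiophen-3-yl therefore cannot be separated in this assay, and the carbonyl substituent shows no preference among these three aromatic rings.

Going by these compounds, all three compounds keep an aromatic ring on the carbonyl carbon, so it remains open whether this flat picture holds for a group of another kind there, such as a saturated ring bearing an amine, a carboxylic acid or a longer alkyl chain. The methoxy group and the shared core are also the same throughout, so these compounds cannot show whether the numbers in this assay respond to a change at either of those places. No accompanying measurement offers an account of why the three numbers lie so close together.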